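This account rests on a few compounds, and the source may have more. Where it says the series, first, only, none or still open, it means among the compounds named here.

In a functional assay on brain (Rattus norvegicus, strain Wistar) for inhibition (on this read-out lower numbers stand for stronger inhibition and higher numbers for weaker inhibition), compound 3 `CCCCCCCCc1ccc(-c2c(C)[nH]c(=O)n2C2CCCCC2)cc1` gives 10300 nM, level within the scatter with compound 2 `Cc1[nH]c(=O)n(C2CCCCC2)c1-c1ccc(CC(C)C)cc1` at 10900 nM. Compound 1 `Cc1[nH]c(=O)n(C2CCCCC2)c1-c1ccccc1`, which has neither chain, gives 47600 nM. Compound 4 `CCCCCCCCOc1ccc(-c2c(C)[nH]c(=O)n2C2CCCCC2)cc1` has octyloxy in place of octyl on an aromatic carbon, para to a large group (octyloxy in place of octyl on an aromatic carbon). Adding isobutyl gave a 4.4-fold lower number from compound 1 to compound 2 (0.64 log units; beyond the scatter) and adding octyl gave a 4.6-fold lower number from compound 1 to compound 3 (0.66 log units; beyond the scatter), both modest steps. Replacing the isobutyl end with the octyl chain gave only a 1.1-fold lower number from compound 2 to compound 3 (0.02 log units; within the scatter). Among the measured compounds shown here, no measured step adds an oxygen, so this evidence is indirect, but compound 4 keeps the octyl length and no clear change is expected in this assay. The expected result is a 1.1-fold lower number from compound 3 to compound 4 (0.06 log units; within the scatter), with no step beyond the scatter. Compound 4 is estimated at 9000 nM, with an expected range of 3500 nM to 22000 nM.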

Compound 4, half-maximal inhibitory concentration: 8500 nM
Compound 4: middle estimate off by 1.1-fold (0.02 log units), on the high side; the measured number falls inside the stated range.
By their numbers in this assay, from the lowest: compounds 4, 3 and 2 (each within the scatter of the next); then compound 1.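

In this assay, octyloxy and octyl read alike at this position, with a 1.2-fold lower number from compound 3 to compound 4 (0.08 log units; within the scatter), so the oxygen and its hydrogen-bond acceptor bring no clear change. Octyloxy also stays level with the shorter isobutyl, with a 1.3-fold lower number from compound 2 to compound 4 (0.11 log units; within the scatter), while keeping the gain over the unsubstituted ring, with a 5.6-fold lower number from compound 1 to compound 4 (0.75 log units; beyond the scatter). No supporting measurement explains why these chains read alike. On these data alone, it remains open whether a shorter butoxy chain would hold this level, and whether an amine or a carboxylic acid at the chain end would change it.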